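Methyl on the aromatic nitrogen of compound 3

A few compounds are considered here, and "the series" means these few. Any claim that something is new, unique, unknown or untested is made for them only; others in the source may bear on it.

- compound 1 `COCCOc1cc(/C=C/c2ccc3ccccc3c2)ccc1OC`: 2990 nM
- compound 2 `COc1cc(/C=C/c2c[nH]c3ccccc23)cc(OC)c1OC`: 3230 nM
- compound 3 `COc1cc(/C=C\c2c[nH]c3ccccc23)cc(OC)c1OC`: 3230 nM

In a functional assay on P388 cells (Mus musculus) for inhibition (on this read-out higher numbers stand for weaker inhibition and lower numbers for stronger inhibition), compound 3 stands level with compound 2, and compound 1 lies within the scatter of both. Compound 4 `COc1cc(/C=C\c2cn(C)c3ccccc23)cc(OC)c1OC`, not yet measured, differs from compound 3 by methyl in place of hydrogen on an aromatic nitrogen. Going by the values given here, the only measured step, no change at the digits printed from compound 2 to compound 3 (within the scatter), concerns the double bond, given (the fact that compounds 2 and 3 differ only in the configuration as drawn). Among the compounds with values here, no measured step touches that nitrogen, so no shift beyond the scatter is expected, though the uncertainty is wide. The expected step is a 1.1-fold lower number from compound 3 to compound 4 (0.03 log units; within the scatter). For compound 4 the estimated value is 3000 nM, with an expected range from 700 nM to 10000 nM.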

Compound 4, half-maximal inhibitory concentration: 3090 nM
For compound 4 the middle estimate is 1.0-fold (0.01 log units) below the measured one; low and high end bracket the measured number.
By their numbers in this assay, from the lowest: compounds 1, 4, 2 and 3 (each within the scatter of the next).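

Methyl in place of hydrogen on the aromatic nitrogen gives, in this assay, a 1.0-fold lower number from compound 3 to compound 4 (0.02 log units; within the scatter). Going by these compounds alone, the hydrogen on that nitrogen is therefore not needed to keep the level of compound 3, a point the earlier compounds, which all differ elsewhere or keep that hydrogen, could not settle. Nothing at hand accounts for this result. On these data alone, whether a longer chain such as propyl, an amine or a carboxylic acid on that nitrogen would hold the same level stays open. So does whether methyl there would behave alike on compound 2.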